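A few compounds are considered here, and "the series" means these few. Any claim that something is new, unique, unknown or untested is made for them only; others in the source may bear on it.

Compound 1 `COc1ccc(Cc2nn(-c3ccccc3)c(=O)c3ccccc23)cc1OC` carries two methoxy groups and is tested in a functional assay on aorta with Alpha-1D adrenergic receptor (Rattus norvegicus) as the target; on this read-out lower numbers stand for an effect already at smaller amounts and higher numbers for an effect only at larger amounts of compound. In this assay compound 1 gives > 100000 nM, which is a limit of the assay and not a number. Compound 2 `CSc1ccc(Cc2nn(-c3ccccc3)c(=O)c3ccccc23)cc1` gives > 100000 nM in this assay, again a limit. Compound 3 `C=CCn1nc(Cc2ccc(SC)cc2)c2ccccc2c1=O` gives > 100000 nM in this assay, also a limit. Within the data shown here, the single step between measured pairs, a step that the two limits leave unreadable from compound 2 to compound 3, cannot be read because the limit of > 100000 nM in this assay, at which 3 of the 3 values shown sit, covers every value shown. Compound 4 `COc1ccc(Cc2nn(-c3ccc([N+](=O)[O-])cc3)c(=O)c3ccccc23)cc1OC` differs from compound 1 by nitro in place of hydrogen on an aromatic carbon. Among the measured compounds shown here, no measured step bears on this change, so no direction can be drawn from the series. For compound 4 the step expected is a number no higher from compound 1 to compound 4 (the limit leaves the size open), nothing beyond the scatter. Compound 4 is estimated at 100000 nM, within 30000 nM to 300000 nM.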

Compound 4, half-maximal effective concentration: > 100000 nM
Compound 4 was reported as a limit (the forecaster's own chance of this, stated with the estimate: 75%); the middle value sits exactly at the limit.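

No step can be read from compound 1 to compound 4, since both values are limits of the assay: the limit of > 100000 nM in this assay, at which 4 of the 4 values shown sit. The compounds shown leave open whether nitro in place of hydrogen, or any other change to the shared core, alters the read-out at all.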